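The source may hold more compounds than are shown below. What is called first, only, known or untested is meant among the compounds shown, and "the series" means these compounds.

In an ADME assay on L929 cells (Mus musculus) for cytotoxicity, read by resazurin assay, with a stated time of 48 h (on this read-out higher numbers stand for lower toxicity in this test and lower numbers for higher toxicity in this test), three compounds sharing one core have been tested, and none gives an exact number. Compound 1 (`O=C(O)CCn1c2ccc([N+](=O)[O-])cc2c(=O)n1Cc1ccccc1`), with a 2-carboxyethyl group on an aromatic nitrogen, gives > 256000 nM, which is a limit of the assay. Compound 2 (`CN(C)C(=O)CCCn1c2ccc([N+](=O)[O-])cc2c(=O)n1Cc1ccccc1`), with a 3-(dimethylcarbamoyl)propyl group on that nitrogen, gives > 256000 nM, also a limit. Compound 3 (`CC(=O)n1c2ccc([N+](=O)[O-])cc2c(=O)n1Cc1ccccc1`), with acetyl there, gives > 256000 nM, again a limit. Compound 3 therefore has no exact position, and all three share (the limit of > 256000 nM in this assay, at which 3 of the 3 values shown sit).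

Compound 4 (`Cc1ccc(S(=O)(=O)n2c3ccc([N+](=O)[O-])cc3c(=O)n2Cc2ccccc2)cc1`) has (4-methylphenyl)sulfonyl in place of the acetyl of compound 3: (4-methylphenyl)sulfonyl in place of acetyl on an aromatic nitrogen. The closest guides are the changes on the same nitrogen, a step that the two limits leave unreadable from compound 1 to compound 3 and a step that the two limits leave unreadable from compound 2 to compound 3, together with the change within the chain, a step that the two limits leave unreadable from compound 1 to compound 2. None of these has a readable size, but across all three groups the read-out stays at the limit. None of those groups carries a ring, however, so this new group goes beyond what has been tested. The expected change is small, an at least 1.2-fold lower number from compound 3 to compound 4 (0.10 log units; that floor lies within the scatter), and any shift is expected towards lower numbers. For compound 4, the estimate is 200000 nM, with an expected range from 80000 nM to 256000 nM.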

Compound 4, concentration lethal to 50% of the cells: > 256000 nM
Compound 4: no number, only a limit; the forecaster's own chance of this, stated with the estimate: 55%; middle value at least 1.2-fold (0.10 log units) from the limit.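

Compound 4 gives only a limit in this assay, as do compound 1, compound 2 and compound 3, so no step among these four compounds can be read. All four share one result: the limit of > 256000 nM in this assay, at which 4 of the 4 values shown sit.

The compounds shown leave open which group on the aromatic nitrogen, if any, would give an exact number in this assay.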